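Swapping Chloro for Methoxy on a Fused Core

The source may report more compounds than this note shows. Statements on the series, on what has been measured and on what is new or still open speak of the compounds shown alone.

Within the data shown here, compound 2 `Clc1cccc2cc3c(nc12)-c1nc2ccccc2n1C3` gives 24000 nM in a functional assay on LNCaP cells (Homo sapiens) for cytotoxicity, read by MTT assay, with a stated time of 72 h (a lower number here means a stronger inhibitor, a higher number a weaker inhibitor), the highest of the two numbers measured so far; compound 1 `Brc1cccc2cc3c(nc12)-c1nc2ccccc2n1C3` gives 8400 nM. Among the measured compounds shown here, the only measured step, a 2.9-fold higher number from compound 1 to compound 2 (0.46 log units; beyond the scatter), exchanges one halogen for another at this same position. Compound 3 `COc1cccc2cc3c(nc12)-c1nc2ccccc2n1C3` differs from compound 2 by methoxy in place of chloro on an aromatic carbon. For the measured compounds named here, no measured step involves methoxy, so the halogen step shows only that changes at this position move this assay modestly. Compound 3 is expected at 15000 nM, within 5000 nM to 50000 nM. The expected step of a 1.6-fold lower number from compound 2 to compound 3 (0.20 log units; within the scatter) is therefore small and uncertain in direction.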

Compound 3, half-maximal inhibitory concentration: 20000 nM
Compound 3: middle estimate off by 1.3-fold (0.12 log units), on the low side; low and high end bracket the measured number.
By their numbers in this assay, from the lowest: compound 1; then compounds 3 and 2 (each within the scatter of the next).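

In this assay, methoxy in place of chloro gives a 1.2-fold lower number from compound 2 to compound 3 (0.08 log units; within the scatter) and so shows that this position can take a group other than a halogen, with a hydrogen-bond acceptor, without a change beyond the scatter. Methoxy in place of bromo gives a 2.4-fold higher number from compound 1 to compound 3 (0.38 log units; beyond the scatter) and so leaves compound 1 with the lowest number of the three, set apart from both others. Nothing available explains why bromo stands apart. Still open, from the compounds shown here alone, is how an amine or a longer chain at this position would read, and whether any group here would go lower than bromo.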